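The compounds below may be only part of what the source reports. "The series", "measured", "known", "first", "only" and "open" are said of these compounds alone.

In an ADME assay on A549 cells (Homo sapiens) for cytotoxicity, read by MTT assay, with a stated time of 48 h (a lower number here means a stronger inhibitor of growth, a higher number a weaker inhibitor of growth), compound 3 `O=C(/C=C/c1c(Cl)cccc1Cl)N1N=C(c2ccncc2)OC1c1c[nH]c2ccccc12` gives only a limit of the assay, > 30 ug/mL, not a number. Compound 1 `O=C(/C=C\c1ccccc1F)N1N=C(c2ccncc2)OC1c1c[nH]c2ccccc12` also gives a limit, > 30 ug/mL. Compound 2 `O=C(/C=C\c1ccc(Cl)cc1Cl)N1N=C(c2ccncc2)OC1c1c[nH]c2ccccc12` likewise gives a limit, > 30 ug/mL. All three values sit at the limit of > 30 ug/mL in this assay, at which 3 of the 3 values shown sit, so the steps among them cannot be read: a step that the two limits leave unreadable from compound 1 to compound 2, a step that the two limits leave unreadable from compound 1 to compound 3 and a step that the two limits leave unreadable from compound 2 to compound 3. Compound 4 `O=C(/C=C\c1cccc(Br)c1)N1N=C(c2ccncc2)OC1c1c[nH]c2ccccc12` has not yet been measured. It differs from compound 3 in one place: 2-(3-bromophenyl)ethenyl in place of 2-(2,6-dichlorophenyl)ethenyl on a carbonyl carbon. The three measured steps bear on this change only in that each of them swaps one substituted phenyl ring at the end of the chain for another, and none of them moved the readout off the limit; that is all the numbers show. The change from compound 3 to compound 4 is of the same kind, so no step beyond the scatter is expected in this assay, and the likeliest outcome is that compound 4 again returns a limit rather than a number. The estimate for compound 4 is 45 ug/mL, between 25 ug/mL and 120 ug/mL, which means an expected step that the limit leaves unreadable from compound 3 to compound 4.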

Compound 4, concentration for 50% growth inhibition: > 30 ug/mL
Compound 4: only a limit was reported (the forecaster's own chance of this, stated with the estimate: 80%); the middle value does not contradict the limit.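

Compound 4 gives only a limit of the assay, > 30 ug/mL, not a number. Its steps to compound 1, compound 2 and compound 3 therefore cannot be read. The compounds shown leave open whether changing the substituted phenyl ring at the end of the chain alters growth inhibition at all in this assay, and by how much.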